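Bromo substitution on two cores in a cytotoxicity series

The source may report more compounds than this note shows. Statements on the series, on what has been measured and on what is new or still open speak of the compounds shown alone.

Measured in a functional assay on cells (Cancer cell lines, Homo sapiens) for cytotoxicity, read by sulforhodamine B assay, with a stated time of 48 h; on this read-out lower numbers stand for stronger inhibition of growth and higher numbers for weaker inhibition of growth:
Compound 1 `O=C1N=C(N2N=C(c3ccccc3)CC2c2ccccc2O)S/C1=C1/C(=O)Nc2ccccc21` gives 4220 nM.
Compound 2 `O=C1N=C(N2N=C(c3ccccc3)CC2c2ccccc2O)S/C1=C1/C(=O)Nc2ccc(Br)cc21` gives 460 nM.
Compound 3 `COc1ccc(C2CC(c3ccc4ccccc4c3)=NN2C2=NC(=O)/C(=C3\C(=O)Nc4ccccc43)S2)cc1` gives 12400 nM.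

Compound 2 differs from compound 1 by bromo in place of hydrogen on an aromatic carbon, and this gave a 9.2-fold lower number from compound 1 to compound 2 (0.96 log units; beyond the scatter). Compound 3 carries a different core; the difference between the two cores is not broken down here. In this assay compound 3 stands highest of the three measured numbers.

Compound 4 `COc1ccc(C2CC(c3ccc4ccccc4c3)=NN2C2=NC(=O)/C(=C3\C(=O)Nc4ccc(Br)cc43)S2)cc1` is not yet measured. It differs from compound 3 by bromo in place of hydrogen on an aromatic carbon, the same change at the same place as between compound 1 and compound 2. For the measured compounds named here, only one example of this change exists in the set, so its transfer to the second core is untested. A step of about a 7.8-fold lower number from compound 3 to compound 4 (0.89 log units; beyond the scatter) is expected, resting on a 9.2-fold lower number from compound 1 to compound 2 (0.96 log units; beyond the scatter), perhaps somewhat attenuated. For compound 4 the estimate in this assay is 1600 nM, expected between 500 nM and 5000 nM.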

Compound 4, concentration for total growth inhibition: 140 nM
Beside the measured number, compound 4's estimate is 11-fold (1.06 log units) above it, outside the stated range (below it).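

In this assay, bromo in place of hydrogen on an aromatic carbon gives an 89-fold lower number from compound 3 to compound 4 (1.95 log units; beyond the scatter) on the second core as well. The direction of the change carries over between these two cores, but its size does not: the same change on two cores in this assay, a 9.2-fold lower number (0.96 log units; beyond the scatter) from compound 1 to compound 2 and an 89-fold lower number (1.95 log units; beyond the scatter) from compound 3 to compound 4, 9.7-fold (0.98 log units) apart, beyond the scatter of two such steps. For the compounds shown here, with only two cores, this sets no rule for other cores and does not show which structural difference between them goes with the larger step.

Still open, going by these compounds, is whether chloro or fluoro at the same place would give a step like that of bromo. Also open, on these data alone, is how an amine or a carboxylic acid at that place would compare on either core.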